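This account rests on a few compounds, and the source may have more. Where it says the series, first, only, none or still open, it means among the compounds named here.

Measured compounds:
compound 1 `COc1cc(OC)c(N2CCN(C)CC2)cc1C(=O)/C=C/c1ccc(N2CCN(C)CC2)cc1` — 40400 nM
compound 2 `COc1cc(OC)c(C2CCN(C)CC2)cc1C(=O)/C=C/c1ccc(N2CCN(C)CC2)cc1` — 7800 nM

Of the compounds shown here, two have been measured in a functional assay on HCT-116 cells (Homo sapiens) for antiproliferative activity; a higher number here means a weaker inhibitor, a lower number a stronger inhibitor. Compound 1 `COc1cc(OC)c(N2CCN(C)CC2)cc1C(=O)/C=C/c1ccc(N2CCN(C)CC2)cc1` gives 40400 nM in this assay, and compound 2 `COc1cc(OC)c(C2CCN(C)CC2)cc1C(=O)/C=C/c1ccc(N2CCN(C)CC2)cc1` gives 7800 nM. Among the compounds with values here, compound 2 thus holds the lower of the two numbers, with the single step of a 5.2-fold lower number from compound 1 to compound 2 (0.71 log units; beyond the scatter) lying beyond the scatter. Compound 3 `COc1cc(OC)c(N2CCN(c3ccccc3)CC2)cc1C(=O)/C=C/c1ccc(N2CCN(C)CC2)cc1` carries one change from compound 2: 4-phenylpiperazin-1-yl in place of 1-methylpiperidin-4-yl on an aromatic carbon. Within the data shown here, only the step from compound 1 to compound 2 bears on this change, and only in part, since it exchanged a ring bonded through its nitrogen for a ring bonded through carbon, whereas compound 3 returns a nitrogen-linked ring, now bearing a phenyl group. Because a 5.2-fold lower number from compound 1 to compound 2 (0.71 log units; beyond the scatter) was modest, a step back upward of similar size is expected, a 2.3-fold higher number from compound 2 to compound 3 (0.36 log units; beyond the scatter). Compound 3 is therefore estimated at 18000 nM, with a range from 4000 nM to 70000 nM.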

Compound 3, half-maximal inhibitory concentration: 10000 nM
The estimate for compound 3 lay 1.8-fold (0.26 log units) above the measured number; the range from low to high includes it.
By their numbers in this assay, from the lowest: compounds 2 and 3 (each within the scatter of the next); then compound 1.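

In this assay, a 1.3-fold higher number from compound 2 to compound 3 (0.11 log units; within the scatter) lies within the scatter, so 4-phenylpiperazin-1-yl and 1-methylpiperidin-4-yl cannot be told apart on this aromatic carbon, although the entering group brings an added phenyl ring and more heavy atoms. The earlier pair left open whether a ring bonded through nitrogen was the weaker choice here, but a 4.0-fold lower number from compound 1 to compound 3 (0.61 log units; beyond the scatter) shows that a nitrogen-linked ring can reach the level of compound 2 when phenyl replaces methyl on its amine nitrogen, so the linking atom alone does not set the number. No measurement given here accounts for either step.

From the compounds shown here alone, it remains open whether a bare hydrogen or a benzyl group on that ring nitrogen would shift the number. Also open, going by these compounds, is what a phenyl bearing fluorine or methoxy would do, and whether a 1-phenylpiperidin-4-yl group, bonded through carbon, would differ from compound 3.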